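The compounds below may be only part of what the source reports. "The series", "measured", "known", "first", "only" and "open" are said of these compounds alone.

In a functional assay (aorta) with Rattus norvegicus as the target, in the presence of a further agent that is not named here (a lower number here means that less compound is needed, a higher number that more compound is needed for the effect), compound 1 (`COC(=O)C1=C(C)N=C(C)/C(=C(/O)OC)C1c1cccc(OCc2c(C)no[n+]2[O-])c1`) gives 400 nM, while compound 2 (`COC(=O)C1=C(C)N=C(C)/C(=C(/O)OC)C1c1ccccc1OCc1c(C)no[n+]1[O-]`) gives 78 nM. Compound 2 therefore holds the lower of the two numbers, and the gap between them lies beyond the scatter. Compound 3 (`COC(=O)C1=C(C)N=C(C)/C(=C(/O)OC)C1c1ccccc1OCc1c(C(N)=O)no[n+]1[O-]`) differs from compound 2 in one place: carbamoyl in place of methyl on an aromatic carbon. This carbon belongs to a five-membered aromatic ring with 2 nitrogen and 1 oxygen, next to the ring atom that bears a large group. Within the data shown here, no measured pair shows this exchange, so the data offer no direct guide and the forecast is uncertain in both directions. A modest shift toward a lower number is expected, with an estimated size of a 2.0-fold lower number from compound 2 to compound 3 (0.29 log units; within the scatter). For compound 3 the estimated value is 40 nM, with an expected range from 8 nM to 200 nM.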

Compound 3, half-maximal effective concentration: 560 nM
Beside the measured number, compound 3's estimate is 14-fold (1.15 log units) below it; the whole stated range lies below it.
By their numbers in this assay, from the lowest: compound 2; then compounds 1 and 3 (each within the scatter of the next).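

Carbamoyl in place of methyl on this aromatic carbon gives a 7.2-fold higher number from compound 2 to compound 3 (0.86 log units; beyond the scatter) in this assay, so this is the first sign that the position is sensitive to what it carries. With methyl, compound 2 needs clearly less compound for the effect, and here the larger carbamoyl, with its hydrogen-bond donor and acceptor, does not match it. This single exchange changes size and hydrogen-bond count together, so it cannot separate them, and nothing measured here explains the shift.

On these data alone, whether a nitrile or a carboxylic acid on this carbon would fall nearer to compound 2 or to compound 3 remains open. As far as these compounds go, it is also open whether the same exchange would move the number in the same direction on compound 1.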